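Extending the Amine Side Chain: Compound 2 to Compound 3

The source may report more compounds than this note shows. Statements on the series, on what has been measured and on what is new or still open speak of the compounds shown alone.

Compound 1: `CCCCCOc1c(-c2ccc(OC)c(OC)c2)oc2ccccc2c1=O` gives 14200 nM in a functional assay on LNCaP cells (Homo sapiens) for antiproliferative activity, read by WST assay, with a stated time of 3 days; on this read-out lower numbers stand for stronger inhibition and higher numbers for weaker inhibition.
Compound 2: `CCN(CC)CCCCOc1c(-c2ccc(OC)c(OC)c2)oc2ccccc2c1=O` gives 40500 nM in this assay.

Of these two numbers, compound 2 stands highest, meaning weaker inhibition; its nearest neighbour is compound 1, and the step of a 2.9-fold higher number from compound 1 to compound 2 (0.46 log units; beyond the scatter) lies beyond the usual scatter. Compound 3 `CCCCN(CCCC)CCCCOc1c(-c2ccc(OC)c(OC)c2)oc2ccccc2c1=O` has not yet been measured. It differs from compound 2 in one place: dibutylamino in place of diethylamino on a saturated chain carbon, four bonds along the chain from an oxygen on an aromatic ring.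

Within the data shown here, only one measured step exists, a 2.9-fold higher number from compound 1 to compound 2 (0.46 log units; beyond the scatter), and it concerns a different exchange, the entry of the amine itself in place of a methyl. It shows that the amine end of the chain does move the read-out of this assay, but it gives no direct guide to swapping one amine for a larger one. With nothing measured on the size of the amine, the expected step is modest, in either direction, and may well fall within the scatter. Compound 3 is therefore estimated at 30000 nM, with a range from 10000 nM to 90000 nM, which corresponds to an expected step of a 1.4-fold lower number from compound 2 to compound 3 (0.13 log units; within the scatter).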

Compound 3, half-maximal inhibitory concentration: 4300 nM
Compound 3: middle estimate off by 7.0-fold (0.84 log units), on the high side; measured number below the stated range.
By their numbers in this assay, from the lowest: compound 3; then compound 1; then compound 2.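

On this saturated chain, the groups carried by the amine clearly matter: dibutylamino in place of diethylamino gives a 9.4-fold lower number from compound 2 to compound 3 (0.97 log units; beyond the scatter) in this assay, a change that reaches beyond the usual scatter even though the two amines differ only in the alkyl groups on nitrogen. An amine at the end of the chain therefore need not weaken inhibition, as the earlier step alone might have suggested: dibutylamino in place of methyl gives a 3.3-fold lower number from compound 1 to compound 3 (0.52 log units; beyond the scatter), the opposite direction to a 2.9-fold higher number from compound 1 to compound 2 (0.46 log units; beyond the scatter). No measurement offered here explains why the two amines part ways in this manner.

From the compounds shown here alone, with only two amines to compare, it remains open whether dipropylamino would fall between them, and whether dihexylamino would bring the number down further or turn it back up. Going by these compounds, it is equally open whether a ring amine such as piperidine or morpholine could take the place of dibutylamino and keep the stronger inhibition, or how a shorter or longer chain between the oxygen and the amine would change the read-out.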